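Solubility notes: thiazole amide series, hydroxymethyl analogue

The source may report more compounds than this note shows. Statements on the series, on what has been measured and on what is new or still open speak of the compounds shown alone.

Compound 3 `CNCc1csc(NC(=O)c2cc(C(C)(C)C)nn2Cc2ccccc2)n1` is the thiazole member of the series and in a physicochemical assay for solubility, read by nephelometry, measured as kinetic solubility, at pH 6.5 (on this read-out higher numbers stand for higher solubility and lower numbers for lower solubility), compound 3 gives 12.5 ug/mL. Among the three measured compounds it has the highest of the numbers, but the comparison carries little weight: the two pyridine amides, compound 1 `CC(C)(C)c1cc(C(=O)Nc2ccncc2)n(Cc2ccccc2)n1` with 6.3 ug/mL and compound 2 `CC(C)(C)c1cc(C(=O)Nc2cccnc2)n(Cc2ccccc2)n1` with 6.3 ug/mL, lie close, and both a 2.0-fold higher number from compound 1 to compound 3 (0.30 log units; within the scatter) and a 2.0-fold higher number from compound 2 to compound 3 (0.30 log units; within the scatter) fall within the scatter, as does no change at the digits printed from compound 1 to compound 2 (within the scatter).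

Compound 4 `CC(C)(C)c1cc(C(=O)Nc2nc(CO)cs2)n(Cc2ccccc2)n1` differs from compound 3 at a single place: hydroxy in place of methylamino on a saturated chain carbon bound to an aromatic carbon. Among the measured compounds shown here, no measured step covers this exchange on its own. The steps that touch the same part of the molecule, from compound 1 or compound 2 to compound 3, replace the whole amide substituent and yet move the read-out only within the scatter; they give no sign that a smaller change at the chain carbon of the thiazole would do more. The expectation is therefore no step beyond the scatter, with a 1.4-fold lower number from compound 3 to compound 4 (0.14 log units; within the scatter) taken as flat.

Compound 4 is accordingly estimated at 9 ug/mL in this assay, with a range from 3 ug/mL to 25 ug/mL.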

Compound 4, solubility: 3.1 ug/mL
Estimate against measurement, compound 4: 2.9-fold (0.46 log units) above; the measured number falls inside the stated range.
By their numbers in this assay, from the lowest: compound 4; then compounds 1, 2 and 3 (each within the scatter of the next).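

In this assay, the exchange of methylamino for hydroxy on a saturated chain carbon bound to an aromatic carbon gives a 4.0-fold lower number from compound 3 to compound 4 (0.61 log units; beyond the scatter). This is the largest step in the series, and it comes from a far smaller edit than the replacements of the whole amide substituent among compounds 1, 2 and 3, which all stay within the scatter. The thiazole amide therefore does not behave as one unit at this position: with the hydroxymethyl group in place of the (methylamino)methyl group, the exchange of the pyridine gives a 2.0-fold lower number from compound 2 to compound 4 (0.31 log units; beyond the scatter) and a 2.0-fold lower number from compound 1 to compound 4 (0.31 log units; beyond the scatter), both modest but beyond the scatter, and nothing at hand gives a measured reason for the drop.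

A single pair cannot tell whether the step belongs to the arrival of hydroxy or to the departure of methylamino; a primary amine, a dimethylamino group, a methoxy group or a carboxylic acid on the same chain carbon would help to separate the two. Going by these compounds, whether a longer chain between the thiazole and the hydroxy or methylamino group keeps a step of this size also remains open.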